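Adding Bromo to a Chlorinated Sulfonamide

The compounds below may be only part of what the source reports. "The series", "measured", "known", "first", "only" and "open" are said of these compounds alone.

Measured in a functional assay on KB cells (Homo sapiens) for antiproliferative activity, read by colorimetric assay and MTT assay; a lower number here means a stronger inhibitor, a higher number a weaker inhibitor:
- Compound 1 `N#Cc1ccc(S(=O)(=O)Nc2cccc3c(Cl)c[nH]c23)cc1`: 11 ug/mL
- Compound 2 `Nc1ccc(S(=O)(=O)Nc2cccc3cc[nH]c23)cc1`: 36 ug/mL
- Compound 3 `Nc1ccc(S(=O)(=O)Nc2cccc3c(Cl)c[nH]c23)cc1`: 10 ug/mL

Compound 3 stands level with compound 1, as a 1.1-fold lower number from compound 1 to compound 3 (0.04 log units; within the scatter) shows, and clearly ahead of compound 2, as a 3.6-fold lower number from compound 2 to compound 3 (0.56 log units; beyond the scatter) shows. Compound 4 `Nc1ccc(S(=O)(=O)Nc2ccc(Br)c3c(Cl)c[nH]c23)cc1` differs from compound 3 by bromo in place of hydrogen on an aromatic carbon, para to a large group. Within the data shown here, no measured step involves bromo. The nearest guide is the modest chloro step, a 3.6-fold lower number from compound 2 to compound 3 (0.56 log units; beyond the scatter), though it lies at another place. The amino step, a 1.1-fold lower number from compound 1 to compound 3 (0.04 log units; within the scatter), says little here. A similar modest drop in this assay is expected, namely a 1.8-fold lower number from compound 3 to compound 4 (0.26 log units; within the scatter). The estimate for compound 4 is 5.5 ug/mL, with an expected range of 2 ug/mL to 14 ug/mL.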

Compound 4, half-maximal inhibitory concentration: 13 ug/mL
Compound 4: the middle estimate sits 2.4-fold (0.37 log units) below what was measured; the range from low to high includes it.
By their numbers in this assay, from the lowest: compounds 3, 1 and 4 (each within the scatter of the next); then compound 2.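

In this assay, bromo in place of hydrogen on this aromatic carbon, para to a large group, gives a 1.3-fold higher number from compound 3 to compound 4 (0.11 log units; within the scatter) and so no readable change. The position therefore tolerates bromo, and the modest step seen for chloro at another place, a 3.6-fold lower number from compound 2 to compound 3 (0.56 log units; beyond the scatter) in that case, does not carry over to this one. Nothing in the data given speaks to why this is so.

Going by these compounds, whether a methoxy group or a carboxylic acid at this place would shift the number remains open. So does whether bromo would behave alike on compound 1, which carries a nitrile instead of the amino group.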